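The source may report more compounds than this note shows. Statements on the series, on what has been measured and on what is new or still open speak of the compounds shown alone.

Working notes on the series. In a functional assay on A549 cells (Homo sapiens) for antiproliferative activity, read by MTT assay, with a stated time of 48 h (a higher number here means a weaker inhibitor, a lower number a stronger inhibitor), compound 1 `Cn1cc(-c2cnc3ccc(NC(=O)C4CC4)nc3c2)cn1` gives > 50000 nM, which is a limit of the assay and not a number. Compound 2 `COc1ccc(CNc2ccc3ncc(-c4cnn(C)c4)cc3n2)cc1` gives > 50000 nM, also a limit. The standing of compound 1 is therefore only this: the limit of > 50000 nM in this assay, at which 2 of the 2 values shown sit. Compound 3 `Cn1cc(-c2cnc3ccc(NS(=O)(=O)c4cccs4)nc3c2)cn1` carries (thiophen-2-yl)sulfonyl in place of cyclopropylcarbonyl on a nitrogen on an aromatic ring. Within the data shown here, no measured step is available to size the change. In this assay a small expected move toward stronger inhibition is all that is assumed, an at least 1.2-fold lower number from compound 1 to compound 3 (0.09 log units; that floor lies within the scatter). For compound 3 the estimated value is 40000 nM, with an expected range of 10000 nM to 100000 nM.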

Compound 3, half-maximal inhibitory concentration: 39500 nM
For compound 3 the middle estimate is 1.0-fold (0.01 log units) above the measured one; the measured number falls inside the stated range.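

Compound 3 is the only compound shown that gives a number and not a limit in this assay, so (thiophen-2-yl)sulfonyl on a nitrogen on an aromatic ring is the one change here that yields a readable value. Going by these compounds, its size stays open: compound 1 stands at a limit, and all that can be stated is an at least 1.2-fold lower number from compound 1 to compound 3 (0.10 log units; that floor lies within the scatter). The other values remain limits: the limit of > 50000 nM in this assay, at which 2 of the 3 values shown sit.

The compounds shown do not separate the part played by the sulfonyl link from that of the thiophene ring. A phenylsulfonyl or methylsulfonyl group on the same nitrogen would bear on this.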